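The compounds below may be only part of what the source reports. "The series", "measured", "known", "first", "only" and "open" are said of these compounds alone.

Measured in an ADME assay on HEK-293T cells (Homo sapiens) for cytotoxicity, read by CCK-8 assay, with a stated time of 48 h; on this read-out higher numbers stand for weaker inhibition and lower numbers for stronger inhibition:
- Compound 1 `O=S(=O)(NCCNC(=S)Nc1cccc(Cl)c1)c1ccc(-c2ccccc2OCc2cccc(O)c2)s1`: 17400 nM
- Compound 2 `O=C(NCCNS(=O)(=O)c1ccc(-c2ccccc2OCc2cccc(O)c2)s1)Nc1cc(Cl)cc(Cl)c1`: > 20000 nM, a limit of the assay
- Compound 3 `O=[N+]([O-])c1ccc(NC(=S)NCCNS(=O)(=O)c2ccc(-c3ccccc3OCc3cccc(O)c3)s2)cc1`: > 20000 nM, a limit of the assay

Compound 2 gives no exact number and stands at the limit of > 20000 nM in this assay, at which 2 of the 3 values shown sit. Compound 4 `O=C(NCCNS(=O)(=O)c1ccc(-c2ccccc2O[C@H]2CC[C@H](O)CC2)s1)Nc1cc(Cl)cc(Cl)c1` has not yet been measured. It differs from compound 2 in one place: 4-hydroxycyclohexyl in place of 3-hydroxybenzyl on an oxygen on an aromatic ring. In words, 4-hydroxycyclohexyl takes the place of 3-hydroxybenzyl on an oxygen on an aromatic ring, so a non-aromatic ring enters where an aromatic ring leaves.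

For the measured compounds named here, none of the measured steps touches the group on this oxygen. They all change the group on the nitrogen, so they bear on the new change only indirectly. The first is an at least 1.1-fold higher number from compound 1 to compound 2 (0.06 log units; that floor lies within the scatter). The second is an at least 1.1-fold higher number from compound 1 to compound 3 (0.06 log units; that floor lies within the scatter). The third is a step that the two limits leave unreadable from compound 2 to compound 3. Together they show no step that is clearly beyond the scatter, and the only exact number is that compound 1 gives 17400 nM.

Going by the values given here, no large step is therefore expected in this assay. The expected change is a step that the limit leaves unreadable from compound 2 to compound 4, which means none beyond the scatter and no firm direction. Another reading at the limit is the likeliest outcome. For compound 4 the estimate is 22000 nM, with an expected range from 11000 nM to 45000 nM.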

Compound 4, half-maximal inhibitory concentration: > 50000 nM
Compound 4: a limit, no number (the forecaster's own chance of this, stated with the estimate: 70%); middle value at least 2.2-fold (0.35 log units) away from the limit.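

No step can be read from compound 2 to compound 4: in this assay each gives only a limit, not an exact number. The compounds shown leave open whether putting 4-hydroxycyclohexyl in place of 3-hydroxybenzyl on this oxygen changes the reading at all and, if it does, in which direction and by how much.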